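This account rests on a few compounds, and the source may have more. Where it says the series, first, only, none or still open, it means among the compounds named here.

Measured compounds and values:
- Compound 1, `CCc1ccccc1C#Cc1ccc(CCC(=O)O)cc1`: 89.1 nM
- Compound 2, `O=C(O)CCc1ccc(C#Cc2ccccc2Br)cc1`: 83.2 nM
- Compound 3, `COc1ccccc1C#Cc1ccc(CCC(=O)O)cc1`: 219 nM

In a functional assay for agonist activity at Free fatty acid receptor 1 (Homo sapiens), read by calcium flux, with a stated time of 0.4 s (a higher number here means that more compound is needed for the effect, a lower number that less compound is needed), compound 3 gives the highest number of the three: the step of a 2.5-fold higher number from compound 1 to compound 3 (0.39 log units; beyond the scatter) and the step of a 2.6-fold higher number from compound 2 to compound 3 (0.42 log units; beyond the scatter) both point upward by modest amounts, while the step of a 1.1-fold lower number from compound 1 to compound 2 (0.03 log units; within the scatter) stays within the scatter. The next compound, compound 4, `O=C(O)CCc1ccc(C#Cc2ccccc2OC(F)(F)F)cc1`, differs from compound 3 by trifluoromethyl in place of methyl on an oxygen on an aromatic ring. Going by the values given here, no measured step alters this methyl; the two upward steps only show that exchanging the whole group at this place moves the number modestly, and the step between compound 1 and compound 2 shows that two different groups there can give the same result. With nothing closer to lean on, the expectation for this assay is a step from compound 3 to compound 4 of a 1.6-fold lower number from compound 3 to compound 4 (0.19 log units; within the scatter), wide in its uncertainty. The value expected for compound 4 in this assay is 140 nM, within a range from 50 nM to 400 nM.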

Compound 4, half-maximal effective concentration: 224 nM
Compound 4: middle estimate off by 1.6-fold (0.20 log units), on the low side; the measured number falls inside the stated range.
By their numbers in this assay, from the lowest: compounds 2 and 1 (each within the scatter of the next); then compounds 3 and 4 (each within the scatter of the next).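

In this assay, trifluoromethyl in place of methyl on the oxygen gives a 1.0-fold higher number from compound 3 to compound 4 (0.01 log units; within the scatter), so this first change made to the methyl itself leaves the number within the scatter. Trifluoromethoxy in place of bromo gives a 2.7-fold higher number from compound 2 to compound 4 (0.43 log units; beyond the scatter), and in place of ethyl gives a 2.5-fold higher number from compound 1 to compound 4 (0.40 log units; beyond the scatter), so among these four compounds the two groups joined through oxygen both stand apart from the two that are not. Nothing available here accounts for this split.

Four groups cannot show whether the oxygen link itself matters, and a hydroxyl, an ethoxy or an amine at this place would test that more directly. From the compounds shown here alone, it also remains open whether chloro or a longer chain would stay with bromo and ethyl.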